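Sulfonamide-linked diamines against pancreatic cancer cells

The compounds below may be only part of what the source reports. "The series", "measured", "known", "first", "only" and "open" are said of these compounds alone.

Compound 1, `O=S(=O)(NCCCCCCNCc1ccc(Br)cc1)c1cccc(C(F)(F)F)c1`, gives 5970 nM in a functional assay on MIA PaCa-2 cells (Homo sapiens) for inhibition, read by MTT assay, with a stated time of 72 h; a higher number here means a weaker inhibitor of growth, a lower number a stronger inhibitor of growth.
Compound 2, `O=S(=O)(NCCCCCCNCc1ccc(Br)cc1)c1ccc2c(c1)OCC2`, gives 13000 nM in this assay.
Compound 3, `O=S(=O)(NCCCNCc1ccccc1)c1cc(C(F)(F)F)cc(C(F)(F)F)c1`, gives 11000 nM in this assay.

Compound 2 has the highest of the three numbers. Compound 3 sits within the scatter of it, so the two cannot be told apart; compound 1 lies at a lower number, beyond the scatter. Compound 4, `O=S(=O)(NCCCCCCNCc1ccc(Br)cc1)c1ccc2ccsc2c1`, is not yet measured and differs from compound 2 in one place: a group of 9 heavy atoms (8 carbon, 1 sulfur; one five-membered aromatic ring with 1 hetero atom, one six-membered aromatic ring of carbon only) in place of a group of 9 heavy atoms (8 carbon, 1 oxygen; one five-membered non-aromatic ring with 1 hetero atom, one six-membered aromatic ring of carbon only), on a sulfonyl sulfur. Within the data shown here, since no measured pair isolates such a change, compound 4 is expected to give a number near that of compound 2, with at most a small downward step that may not exceed the scatter, so the expected step is a 1.6-fold lower number from compound 2 to compound 4 (0.21 log units; within the scatter). The estimate for compound 4 is 8000 nM, in the range 3500 nM to 18000 nM.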

Compound 4, concentration for 50% growth inhibition: 6000 nM
Compound 4: the middle estimate sits 1.3-fold (0.12 log units) above what was measured; low and high end bracket the measured number.
By their numbers in this assay, from the lowest: compounds 1, 4, 3 and 2 (each within the scatter of the next, the first and the last beyond it).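

In this assay, among these compounds, the group on the sulfonyl sulfur gives the first change that can be read on its own: 1-benzothiophen-6-yl there brings a 2.2-fold lower number from compound 2 to compound 4 (0.34 log units; beyond the scatter), a modest step. Both groups carry the same counts of heavy atoms and hydrogen-bond acceptors, so this position responds to a change that leaves those counts equal. Nothing measured here accounts for the step.

Going by these compounds, whether it follows the sulfur or the aromatic five-membered ring remains open; 1-benzofuran-6-yl at this position would separate the two. Also open, on these data alone, is how a carboxylic acid on this group would read.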